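Same atoms, different drawn configuration: compound 1 to compound 4

The source may hold more compounds than are shown below. What is called first, only, known or untested is meant among the compounds shown, and "the series" means these compounds.

Of the compounds shown here, three have numbers so far in a functional assay on MDA-MB-231 cells (Homo sapiens) for cytotoxicity, read by sulforhodamine B assay; on this read-out higher numbers stand for weaker inhibition of growth and lower numbers for stronger inhibition of growth. Compound 1 `O=C(NCCCCCNC(=O)C1=NO[C@]2(C=C(Br)C(=O)[C@@H](Br)[C@@H]2O)C1)C1=NO[C@]2(C=C(Br)C(=O)[C@@H](Br)[C@@H]2O)C1` gives 2100 nM, the lowest of the three and so the strongest growth inhibition, clearly apart from the other two. Compound 2 `COC1=C(Br)[C@H](O)[C@@]2(C=C1Br)CC(C(=O)NCCCCCNC(=O)C1=NO[C@]3(C=C(Br)C(OC)(OC)[C@@H](Br)[C@@H]3O)C1)=NO2` gives 6000 nM, and compound 3 `COC1=C(Br)[C@H](O)[C@@]2(C=C1Br)CC(C(=O)NCCCCCNC(=O)C1=NO[C@]3(C=C(Br)C(=O)[C@H](Br)[C@@H]3O)C1)=NO2` gives 4900 nM. These last two values cannot be told apart.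

The unmeasured compound 4 `O=C(NCCCCCNC(=O)C1=NO[C@]2(C=C(Br)C(=O)[C@H](Br)[C@@H]2O)C1)C1=NO[C@]2(C=C(Br)C(=O)[C@H](Br)[C@@H]2O)C1` has the same atoms and bonds as compound 1, and the whole change lies in its three-dimensional arrangement: the two compounds have the same atoms and bonds and differ only in configuration as drawn: 2 of 6 stereo elements differ; a stereocentre at a saturated ring carbon is drawn S in compound 1 and R in compound 4; a stereocentre at a saturated ring carbon is drawn S in compound 1 and R in compound 4. Among the measured compounds shown here, no pair of measured compounds isolates a change of this kind, so the data give no direct guide to its size. The measured numbers do span a narrow band, from compound 1 at 2100 nM to compound 2 at 6000 nM. Compound 1 sits at the low end of that band, so a small move toward weaker inhibition in this assay seems most likely. The estimated step is a 1.7-fold higher number from compound 1 to compound 4 (0.22 log units; within the scatter). For compound 4 the expected value is 3500 nM, with an estimated range of 1500 nM to 8000 nM.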

Compound 4, concentration for total growth inhibition: 2400 nM
Estimate against measurement, compound 4: 1.5-fold (0.16 log units) above; the range from low to high includes it.
By their numbers in this assay, from the lowest: compounds 1 and 4 (each within the scatter of the next); then compounds 3 and 2 (each within the scatter of the next).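

In this assay, the measured step is a 1.1-fold higher number from compound 1 to compound 4 (0.06 log units; within the scatter): drawing both stereocentres at saturated ring carbons as R rather than S leaves the number inside the usual scatter. Among the compounds shown here, the earlier compounds offered no pair changed in a single place, and this is the first direct reading of any single change. On this read-out, these two configurations cannot be told apart, and the comparison concerns configuration alone: the fact that compounds 1 and 4 differ only in the configuration as drawn

The compounds shown leave open whether inverting only one of these stereocentres would give the same result, as both change together in this pair. They also leave open how the number would respond to chlorine in place of the bromine, or to a longer chain in place of the present linking chain.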